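A Methoxy Swap in a Flat Series

A few compounds are considered here, and "the series" means these few. Any claim that something is new, unique, unknown or untested is made for them only; others in the source may bear on it.

In a functional assay on MGC-803 cells (Homo sapiens) for cytotoxicity, read by MTT assay, with a stated time of 72 h (a higher number here means a weaker inhibitor, a lower number a stronger inhibitor), compound 1 (`O=C1C(=Cc2ccc(Br)cc2)C(=O)N(c2ccc(Cl)cc2)N1c1ccc(Cl)cc1`) gives 16900 nM and compound 2 (`COc1cc(C=C2C(=O)N(c3ccc(Cl)cc3)N(c3ccc(Cl)cc3)C2=O)ccc1O`) gives 21800 nM while compound 3 (`O=C1C(=Cc2cccc(Cl)c2)C(=O)N(c2ccc(Cl)cc2)N1c1ccc(Cl)cc1`) gives 14400 nM on the same scale. Compound 3 thus stands within the scatter of both others. Compound 4 (`COc1cccc(C=C2C(=O)N(c3ccc(Cl)cc3)N(c3ccc(Cl)cc3)C2=O)c1`), not yet measured, carries methoxy in place of chloro on an aromatic carbon. Three measured exchanges of the aromatic group bear on it, and each stays within the scatter: a 1.2-fold lower number from compound 1 to compound 3 (0.07 log units; within the scatter) and a 1.3-fold higher number from compound 1 to compound 2 (0.11 log units; within the scatter) and a 1.5-fold lower number from compound 2 to compound 3 (0.18 log units; within the scatter) by the numbers. No step beyond the scatter is therefore expected in this assay for this swap. The expected step is a 1.1-fold higher number from compound 3 to compound 4 (0.05 log units; within the scatter) by this estimate. Compound 4 is expected at 16000 nM with 7000 nM to 35000 nM as the estimated range.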

Compound 4, half-maximal inhibitory concentration: 26600 nM
Compound 4: the middle estimate sits 1.7-fold (0.22 log units) below what was measured; measured number inside the range.
By their numbers in this assay, from the lowest: compounds 3, 1, 2 and 4 (each within the scatter of the next).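

In this assay the new compound adds a 1.8-fold higher number from compound 3 to compound 4 (0.27 log units; within the scatter) for methoxy in place of chloro, a 1.2-fold higher number from compound 2 to compound 4 (0.09 log units; within the scatter) for hydrogen in place of hydroxy and a 1.6-fold higher number from compound 1 to compound 4 (0.20 log units; within the scatter) for 3-methoxyphenyl in place of 4-bromophenyl. This position, on an aromatic carbon meta to a large group, thus accepts methoxy as well as chloro, and dropping the hydroxy of compound 2 moves nothing beyond the scatter. No measurement bearing on the reason for this flatness is available. Going by these compounds, whether an amine, a carboxylic acid or a longer chain here would leave the scatter stays open.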